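A Smaller Ring on the Carbonyl Carbon of Compound 2

The source may report more compounds than this note shows. Statements on the series, on what has been measured and on what is new or still open speak of the compounds shown alone.

Measured compounds in an assay for inhibition of cholesterol 24-hydroxylase (Homo sapiens), using NADPH, with stated times of 15 min and 5 min; on this read-out lower numbers stand for stronger inhibition and higher numbers for weaker inhibition:
compound 1, `Cc1ccccc1C1=NN(C(=O)c2ccncc2)C(C)(C)C1`, 60 nM
compound 2, `COC(=O)c1cc(C)ccc1-c1ccncc1`, 1900 nM
compound 3, `COC1(Cc2ccccc2)CCN(C(=O)c2cc(C)ccc2-c2ccncc2)CC1`, 74 nM

Compound 2 stands highest of the three numbers in this assay. Its nearest neighbour is compound 3 with 74 nM, and the furthest is compound 1 with 60 nM; both gaps lie beyond the scatter.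

Compound 4, `Cc1ccc(-c2ccncc2)c(C(=O)N2CCC(O)CC2)c1`, differs from compound 2 by 4-hydroxypiperidin-1-yl in place of methoxy on a carbonyl carbon. Among the measured compounds shown here, no measured pair shows this exact change. A drop beyond the scatter is nevertheless expected, estimated as a 4.8-fold lower number from compound 2 to compound 4 (0.68 log units; beyond the scatter), because compound 3, which also replaces the methoxy on that carbonyl carbon with a ring, gives 74 nM. Compound 4 is therefore expected at 400 nM, within a range from 100 nM to 1500 nM.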

Compound 4, half-maximal inhibitory concentration: 7700 nM
Compound 4: middle estimate off by 19-fold (1.28 log units), on the low side; measured number outside the range, above it.
By their numbers in this assay, from the lowest: compounds 1 and 3 (each within the scatter of the next); then compound 2; then compound 4.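

Placing a ring on this carbonyl carbon does not by itself lower the number: 4-hydroxypiperidin-1-yl in place of methoxy gives a 4.1-fold higher number from compound 2 to compound 4 (0.61 log units; beyond the scatter). The piperidine amide alone therefore does not secure a low number, as compound 3 gives 74 nM while compound 4 gives 7700 nM, so the outcome depends on what the ring carries. Nothing available explains the rise from methoxy to 4-hydroxypiperidin-1-yl. From the compounds shown here alone, whether a piperidine ring carrying an amine or a carboxylic acid in place of the hydroxy group would stand nearer compound 3 or compound 4 remains open.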